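This account rests on a few compounds, and the source may have more. Where it says the series, first, only, none or still open, it means among the compounds named here.

Measured compounds:
compound 1 `CC1CCN(C2CCN(S(=O)(=O)c3ccc(F)cc3F)CC2)CC1` with 102 nM
compound 2 `CC1CCN(C2CCN(S(=O)(=O)c3ccc(OCc4ccccc4)cc3)CC2)CC1` with 385 nM
compound 3 `CCc1cc(Br)ccc1S(=O)(=O)N1CCC(N2CCC(C)CC2)CC1` with 0.6 nM

The three compounds share a core and differ only in the substituents on the arylsulfonyl ring. In a functional assay on DLD-1 cells (Homo sapiens) for antiproliferative activity, read by CellTiter-Glo, with a stated time of 72 h (on this read-out lower numbers stand for stronger inhibition and higher numbers for weaker inhibition), compound 2 gives the highest of the three numbers. Its nearest neighbour is compound 1, whose value of 102 nM lies beyond the scatter from it. Compound 3, with 0.6 nM, lies far beyond it, so the substitution pattern on this ring clearly governs the read-out, though no two of the measured compounds differ in a single place.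

Compound 4 `CC1CCN(C2CCN(S(=O)(=O)c3ccc(-c4ccccc4)cc3)CC2)CC1` has not yet been measured. It differs from compound 2 as follows: phenyl in place of benzyloxy on an aromatic carbon The change sits on the same aromatic carbon, para to a large group, and keeps one aromatic ring while dropping the link that carried it.

Within the data shown here, because compound 2 gives 385 nM and no measured pair isolates this kind of change, the step is expected to be modest, most likely toward a lower number, but not clearly beyond the scatter. The step of a 1.9-fold lower number from compound 2 to compound 4 (0.28 log units; within the scatter) expresses this expectation. For compound 4 the estimate is 200 nM, with a range from 40 nM to 1000 nM.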

Compound 4, half-maximal inhibitory concentration: 258 nM
Beside the measured number, compound 4's estimate is 1.3-fold (0.11 log units) below it; the measured number falls inside the stated range.
By their numbers in this assay, from the lowest: compound 3; then compound 1; then compounds 4 and 2 (each within the scatter of the next).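

This is the first pair among the compounds shown that differs in a single place, so it gives the first direct reading of a change on this aromatic carbon, para to a large group. In this assay, the exchange of benzyloxy for phenyl gives a step, a 1.5-fold lower number from compound 2 to compound 4 (0.17 log units; within the scatter), so the two compounds cannot be told apart on this read-out, although the entering group lacks the oxygen and the hydrogen-bond acceptor of the leaving group and has fewer heavy atoms. Nothing available bears on why the read-out responds in this way.

The compounds shown leave open whether a group of another kind on this same carbon, such as an amine, a carboxylic acid or a longer chain carrying the aromatic ring, would move the number beyond the scatter. They also leave open how much of the wide spread across the set belongs to this carbon, since compound 1 and compound 3 each differ from the others in more than one place.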